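Cyclopropyl for methyl on the sulfonyl: a permeability estimate

The source may report more compounds than this note shows. Statements on the series, on what has been measured and on what is new or still open speak of the compounds shown alone.

Measured compounds:
compound 1 `Cn1cc(-c2ccc(C(F)(F)F)cc2)c2cc(F)c(C(=O)NS(=O)(=O)C3CC3)cc21`: 46 nm/s
compound 2 `CC(C)COc1ccc(-c2cn(C)c3cc(C(=O)NS(C)(=O)=O)c(F)cc23)cn1`: 61 nm/s
compound 3 `Cn1cc(-c2ccc(C(F)(F)F)cc2)c2cc(F)c(C(=O)NS(C)(=O)=O)cc21`: 20 nm/s

Three compounds were tested in an ADME assay on Caco-2 cells (Homo sapiens) for permeability, in the apical to basolateral direction; a lower number here means that the compound crosses the layer more slowly, a higher number that the compound crosses the layer faster. In this assay compound 3 gives 20 nm/s, compound 1 gives 46 nm/s and compound 2 gives 61 nm/s. Compound 2 and compound 1 lie within the usual scatter of each other, while compound 2 sits beyond the scatter above compound 3.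

Compound 1 differs from compound 3 in one place only: cyclopropyl in place of methyl on a sulfonyl sulfur. That change brought a 2.3-fold higher number from compound 3 to compound 1 (0.36 log units; beyond the scatter).

Compound 4 `CC(C)COc1ccc(-c2cn(C)c3cc(C(=O)NS(=O)(=O)C4CC4)c(F)cc23)cn1` is not yet measured. It differs from compound 2 in the same place and in the same way: cyclopropyl in place of methyl on a sulfonyl sulfur. The difference between the core of compound 2 and the core of compound 3 is not broken down here, so the change is made on a different core this time, but around the sulfonyl sulfur the surroundings read the same.

Among the measured compounds shown here, from compound 2 to compound 4 a step of about a 1.8-fold higher number from compound 2 to compound 4 (0.26 log units; within the scatter) is expected, resting on the single earlier step of a 2.3-fold higher number from compound 3 to compound 1 (0.36 log units; beyond the scatter) and on the starting point of compound 2 at 61 nm/s. For the measured compounds named here, since only one prior example of the change is available, the range is kept wide. For compound 4 in this assay the estimate is 110 nm/s, with a likely span from 60 nm/s to 200 nm/s.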

Compound 4, apparent permeability: 120 nm/s
Estimate against measurement, compound 4: 1.1-fold (0.04 log units) below, and the stated range covers the measured number.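

In this assay, cyclopropyl in place of methyl on the sulfonyl sulfur gave a 2.0-fold higher number from compound 2 to compound 4 (0.29 log units; within the scatter), so on the new core the step taken alone stays inside the usual spread of repeated measurements. Its weight comes from the comparison with the earlier step, which shows that the change carried over from one core to the other in the same direction and at much the same size, the two steps being indistinguishable: the same change on two cores in this assay, a 2.3-fold higher number (0.36 log units; beyond the scatter) from compound 3 to compound 1 and a 2.0-fold higher number (0.29 log units; within the scatter) from compound 2 to compound 4, 1.2-fold (0.07 log units) apart, within the scatter of two such steps This agreement rests on one pair of cores in one assay, so it supports transfer between these two cores but does not establish a rule for the whole series, and it does not explain why the number rises.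

The compounds shown carry only methyl or cyclopropyl on the sulfonyl sulfur, so it remains open whether an open chain such as ethyl or isopropyl, a larger carbon ring such as cyclobutyl, or a group bearing an amine or a carboxylic acid would follow the same course. As far as these compounds go, it also remains open whether the step would hold on a third core.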